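This account rests on a few compounds, and the source may have more. Where it says the series, first, only, none or still open, it means among the compounds named here.

Measured so far:
Compound 1 `CC(=O)N1N=C(c2ccc(N3CCN(C)CC3)cc2)CC1c1ccc(N(C)C)cc1` – in a functional assay on HCC1806 cells (Homo sapiens) for inhibition, read by sulforhodamine B assay, tested at 10 uM (on this read-out higher numbers stand for more inhibition at the one concentration tested (going by the name of the read-out) and lower numbers for less inhibition), compound 1 gives -0.8%.
Compound 2 `CN1CCN(c2ccc(C3=NN(S(=O)(=O)c4ccc(F)cc4)C(c4ccc(N(C)C)cc4)C3)cc2)CC1` – in this assay compound 2 gives 92.3%.

Within the data shown here, compound 2 stands highest of the two numbers; the single step, a number 93.1 percentage points higher from compound 1 to compound 2 (beyond the scatter), sets it well apart from compound 1. Compound 3 `CN1CCN(c2ccc(C3=NN(S(=O)(=O)c4ccc(Br)cc4)C(c4ccc(N(C)C)cc4)C3)cc2)CC1` differs from compound 2 only by bromo in place of fluoro on an aromatic carbon, turning the (4-fluorophenyl)sulfonyl into a (4-bromophenyl)sulfonyl. Among the measured compounds shown here, no measured step concerns this exchange; the one step from compound 1 to compound 2 changed a different group. The expected step is therefore small, a number 4.3 percentage points lower from compound 2 to compound 3 (within the scatter), within the scatter. Compound 3 is estimated at 88%, between 65% and 100%.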

Compound 3, a percentage reported as inhibition, at one concentration (the size of the read-out at that concentration, not a potency): 87.1%
Beside the measured number, compound 3's estimate is 0.9 percentage points above it; the range from low to high includes it.
By their numbers in this assay, from the lowest: compound 1; then compounds 3 and 2 (each within the scatter of the next).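

In this assay, the halogen on the aryl sulfonyl group can be exchanged with only a number 5.2 percentage points lower from compound 2 to compound 3 (within the scatter). The large gain over the acetyl compound holds with bromo as it does with fluoro, at a number 87.9 percentage points higher from compound 1 to compound 3 (beyond the scatter). Nothing measured here explains either result.

The compounds shown leave open how a methoxy group or a nitrile would fare on that aromatic carbon. They also leave open whether an alkyl sulfonyl group such as methylsulfonyl would hold the level of compound 2 and compound 3.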